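This account rests on a few compounds, and the source may have more. Where it says the series, first, only, none or still open, it means among the compounds named here.

Measured in a functional assay on the whole organism for antagonist activity, with Mus musculus as the target; a higher number here means that more compound is needed for the effect, a lower number that less compound is needed:
- Compound 1 `CC(=O)N(C)CC#CCn1ccnc1`: > 100 mg/kg (a limit)
- Compound 2 `CCOC(=O)N(C)CC#CCn1ccnc1`: > 100 mg/kg (a limit)
- Compound 3 `CCOC(=O)N(C)CC#CCn1cncc1C`: 30 mg/kg

In this assay compound 2 gives > 100 mg/kg, which is a limit and not a number. It sits at the limit of > 100 mg/kg in this assay, at which 2 of the 3 values shown sit. Compound 4 `CN(C)C(=O)N(C)CC#CCn1ccnc1` carries dimethylamino in place of ethoxy on a carbonyl carbon.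

For the measured compounds named here, two measured steps bear on this change. The closer one, on the same carbonyl carbon, is a step that the two limits leave unreadable from compound 1 to compound 2, so it gives no size to build on. The other is an at least 3.3-fold lower number from compound 2 to compound 3 (0.52 log units; beyond the scatter), made by methyl in place of hydrogen on an aromatic carbon, and compound 4 lacks that change. No step beyond the scatter is therefore expected in this assay, and a report at the limit is likely.

The expected step is a step that the limit leaves unreadable from compound 2 to compound 4.

For compound 4 the estimated value is 130 mg/kg, with an expected range from 50 mg/kg to 300 mg/kg.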

Compound 4, dose for half-maximal effect: > 100 mg/kg
Compound 4: no number, only a limit; the forecaster's own chance of this, stated with the estimate: 80%; the middle value lies beyond the limit too.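

Compound 4 also gives only a limit, so its steps from compound 1 and compound 2 cannot be read: the limit of > 100 mg/kg in this assay, at which 3 of the 4 values shown sit. As far as these compounds go, whether methyl, ethoxy or dimethylamino on the carbonyl carbon changes the result in this assay stays open.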